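Swapping methoxy for dimethylamino on a long chain

The compounds below may be only part of what the source reports. "The series", "measured", "known", "first", "only" and "open" are said of these compounds alone.

Within the data shown here, in a functional assay on HCT-116 cells (Homo sapiens) for antiproliferative activity, read by MTT assay, with a stated time of 48 h (a lower number here means a stronger inhibitor, a higher number a weaker inhibitor), compound 3 `CCCCCCCCCC(CCO)n1cnc2c(OC)ncnc21` gives 2530 nM as the only true number in this small set. Compound 1 `CCCCCCC(CCO)n1cnc2c(N(C)C)ncnc21` gives > 50000 nM as a limit of the assay. Compound 2 `CCCCCCCC(CCO)n1cnc2c(N(C)C)ncnc21` gives > 50000 nM as a limit too. Both carry the dimethylamino group of compound 4 `CCCCCCCCCC(CCO)n1cnc2c(N(C)C)ncnc21` on shorter chains. Among the measured compounds shown here, the one measured step, a step that the two limits leave unreadable from compound 1 to compound 2, gives no size to work with.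

Compound 4 keeps the chain of compound 3 and changes one group: dimethylamino in place of methoxy on an aromatic carbon. For the measured compounds named here, no measured step isolates this swap, so the data offer only a weak guide. Going by the values given here, with compound 3 at 2530 nM as the anchor and no dimethylamino compound yet giving a number, a modest loss of strength in this assay is expected, with a wide margin. The estimated change is a 2.4-fold higher number from compound 3 to compound 4 (0.38 log units; beyond the scatter) for this swap. Compound 4 is estimated at 6000 nM within an expected range of 1800 nM to 25000 nM in this test.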

Compound 4, half-maximal inhibitory concentration: 9810 nM
Compound 4: the middle estimate sits 1.6-fold (0.21 log units) below what was measured; measured number inside the range.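

With the chain held the same, the data now show a 3.9-fold higher number from compound 3 to compound 4 (0.59 log units; beyond the scatter) for dimethylamino in place of methoxy on this aromatic carbon, the first readable size for this change. Chain length also matters with dimethylamino in place, since ethyl on the chain gives an at least 5.0-fold lower number from compound 2 to compound 4 (0.70 log units; beyond the scatter) and propyl gives an at least 5.0-fold lower number from compound 1 to compound 4 (0.70 log units; beyond the scatter) in this assay. These two chain steps are bounds rather than full sizes, and the step between the two shorter chains cannot be read: the limit of > 50000 nM in this assay, at which 2 of the 4 values shown sit.

Still open, going by these compounds, is how other groups on this aromatic carbon, such as a plain amino group or an ethoxy group, would compare with methoxy and dimethylamino. Also open, on these data alone, is whether a longer chain would lower the number further, and whether methoxy on the shorter chains would follow the same trend.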